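Swapping a Hydroxyphenyl for Thiophene in a Hydrazone Series

A few compounds are considered here, and "the series" means these few. Any claim that something is new, unique, unknown or untested is made for them only; others in the source may bear on it.

Compound 3 (`O=C(CSc1nnc(-c2ccncc2)o1)N/N=C/c1ccccc1O`) gives the lowest number of the three measured compounds in a functional assay on SW 1116 cells (Homo sapiens) for cytotoxicity, read by MTT assay, with a stated time of 48 h (on this read-out higher numbers stand for weaker inhibition and lower numbers for stronger inhibition), at 7380 nM. Its nearest neighbour is compound 1 (`O=C(CSc1nnc(-c2ccncc2)o1)N/N=C/c1ccc(Br)cc1`), which gives 21300 nM in this assay, and the furthest is compound 2 (`O=C(CSc1nnc(-c2ccncc2)o1)N/N=C/c1cccc(F)c1`), which gives 26700 nM. The steps of a 2.9-fold lower number from compound 1 to compound 3 (0.46 log units; beyond the scatter) and a 3.6-fold lower number from compound 2 to compound 3 (0.56 log units; beyond the scatter) both point the same way, while the step of a 1.3-fold higher number from compound 1 to compound 2 (0.10 log units; within the scatter) does not separate those two compounds.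

Compound 4 (`O=C(CSc1nnc(-c2ccncc2)o1)N/N=C/c1cccs1`) is the next compound to be measured in this assay. The change from compound 3 is thiophen-2-yl in place of 2-hydroxyphenyl on a carbon with a double bond to nitrogen. Within the data shown here, no measured step replaces the 2-hydroxyphenyl with a five-membered ring, so the bearing of the data is indirect: the only pair of steps available, a 2.9-fold lower number from compound 1 to compound 3 (0.46 log units; beyond the scatter) and a 3.6-fold lower number from compound 2 to compound 3 (0.56 log units; beyond the scatter), show that the 2-hydroxyphenyl is tied to the lowest number in the set, and its removal is therefore expected to give back a higher number, of modest size, rather than a further drop.

The estimate for compound 4 is a step of a 2.4-fold higher number from compound 3 to compound 4 (0.39 log units; beyond the scatter), landing near the numbers of compounds 1 and 2, with a value expected at 18000 nM and a range from 7000 nM to 45000 nM.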

Compound 4, half-maximal inhibitory concentration: 24900 nM
Beside the measured number, compound 4's estimate is 1.4-fold (0.14 log units) below it, within the range that was stated.
By their numbers in this assay, from the lowest: compound 3; then compounds 1, 4 and 2 (each within the scatter of the next).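

In this assay, thiophen-2-yl in place of 2-hydroxyphenyl gives a 3.4-fold higher number from compound 3 to compound 4 (0.53 log units; beyond the scatter), so the gap that earlier separated compound 3 from two halogen-bearing phenyl compounds also appears with a five-membered aromatic ring that carries sulfur and has no hydrogen-bond donor. Compound 4 does not separate from those halogen-bearing compounds, with a 1.1-fold lower number from compound 2 to compound 4 (0.03 log units; within the scatter) and a 1.2-fold higher number from compound 1 to compound 4 (0.07 log units; within the scatter), so at this place on the carbon with a double bond to nitrogen, 4-bromophenyl, 3-fluorophenyl and thiophen-2-yl cannot be told apart despite their different rings and atoms, and only compound 3 stands out from the other three. Nothing available here accounts for the position of compound 3 in this set.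

The compounds shown leave open whether the lower number belongs to the hydroxyl group itself or depends on the six-membered ring that carries it. An unsubstituted phenyl, a methoxyphenyl or an aminophenyl at this place would bear directly on that question, and a hydroxyl-bearing thiophene would test whether the same group works on the five-membered ring.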